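Methoxy to Ethoxy: Cytotoxicity Expected to Stay at the Limit

The source may report more compounds than this note shows. Statements on the series, on what has been measured and on what is new or still open speak of the compounds shown alone.

Compound 1 `Cc1c(Oc2ccccc2OCCn2ccc(=O)[nH]c2=O)cc(C(C)C)c2ccc(C#N)cc12` carries an isopropyl group on its core, and in a toxicity assay on MT2 cells (Homo sapiens) for cytotoxicity, read by MTT assay (on this read-out lower numbers stand for higher toxicity in this test and higher numbers for lower toxicity in this test), compound 1 gives 9000 nM. Compound 2 `COc1cc(Oc2ccccc2OCCn2ccc(=O)[nH]c2=O)c(C)c2cc(C#N)ccc12` differs by a methoxy in place of isopropyl on an aromatic carbon. For compound 2 this assay reports only a limit, > 100000 nM. The step of an at least 11-fold higher number from compound 1 to compound 2 (1.04 log units; beyond the scatter) is thus known only as a bound, because one of the two values sits at the limit of > 100000 nM in this assay, at which 1 of the 2 values shown sits.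

Compound 3 `CCOc1cc(Oc2ccccc2OCCn2ccc(=O)[nH]c2=O)c(C)c2cc(C#N)ccc12` takes the next step: methyl in place of hydrogen on a saturated chain carbon bound to an oxygen on an aromatic ring. Among the compounds with values here, no measured step covers this change; the isopropyl-to-methoxy step says nothing about methoxy to ethoxy, and compound 2 already stands at the limit of this assay. Compound 3 is therefore expected to remain near that limit, with a step of a number no higher from compound 2 to compound 3 (the limit leaves the size open). The estimated value for compound 3 in this assay is 100000 nM, between 40000 nM and 250000 nM, and the test may again report only a limit.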

Compound 3, half-maximal cytotoxic concentration: > 100000 nM
Compound 3 ended at the assay's limit; the forecaster's own chance of this, stated with the estimate: 70%; the middle value sits exactly at the limit.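

In this assay compound 3 gives > 100000 nM, which is a limit of the assay and not a number. Swapping the isopropyl group for ethoxy gives an at least 11-fold higher number from compound 1 to compound 3 (1.04 log units; beyond the scatter), so the large step first seen with methoxy also appears with ethoxy, and it is not confined to that one group. The step for methyl in place of hydrogen on the saturated chain carbon bound to an oxygen on an aromatic ring cannot be read, and the two compounds that carry methoxy and ethoxy share one limit: the limit of > 100000 nM in this assay, at which 2 of the 3 values shown sit.

The compounds shown leave open how the true values of compound 2 and compound 3 compare, since neither has a number. Also open, as far as these compounds go, is whether a longer chain such as propoxy, or an amine, on that aromatic carbon would stay at this limit or bring the number back toward that of compound 1.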